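A few compounds are considered here, and "the series" means these few. Any claim that something is new, unique, unknown or untested is made for them only; others in the source may bear on it.

Measured so far:
compound 1, `Cn1c(=O)ccn([C@@H]2O[C@H](COP(=O)(O)OP(=O)(O)OP(=O)(O)O)[C@@H](O)[C@H]2O)c1=O`, 2920 nM
compound 2, `Cn1c(=O)ccn([C@@H]2O[C@H](COP(=O)(O)OP(=O)(O)O)[C@@H](O)[C@H]2O)c1=O`, > 100000 nM
compound 3, `Cc1cc(=O)n([C@@H]2O[C@H](COP(=O)(O)OP(=O)(O)O)[C@@H](O)[C@H]2O)c(=O)[nH]1`, > 100000 nM

In an in vitro functional assay on 1321-N1 cells for agonist activity at P2Y purinoceptor 4 (Homo sapiens) (a lower number here means that less compound is needed, a higher number that more compound is needed for the effect), compound 1 gives 2920 nM. For compound 2 the assay reports only a limit, > 100000 nM. The change between them is a hydrogen atom in place of a group of 4 heavy atoms (3 oxygen, 1 phosphorus; no ring), on an oxygen, and it brought an at least 34-fold higher number from compound 1 to compound 2 (1.53 log units; beyond the scatter). For compound 3 the assay likewise reports only a limit, > 100000 nM. The difference between the core of compound 1 and the core of compound 3 is not broken down here. Compound 4, `Cc1cc(=O)n([C@@H]2O[C@H](COP(=O)(O)O)[C@@H](O)[C@H]2O)c(=O)[nH]1`, is not yet measured; it differs from compound 3 by a hydrogen atom in place of a group of 4 heavy atoms (3 oxygen, 1 phosphorus; no ring), on an oxygen, the same change as between compound 1 and compound 2. Because of the limit of > 100000 nM in this assay, at which 2 of the 3 values shown sit, the starting point already sits at a limit, so compound 4 is expected to remain there, the step that the limit leaves unreadable from compound 3 to compound 4 being an estimate only. For compound 4 the expected value is 200000 nM.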

Compound 4, half-maximal effective concentration: > 100000 nM
Compound 4 ended at the assay's limit; the forecaster's own chance of this, stated with the estimate: 95%; the middle value lies beyond the limit too.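

In this assay compound 3 and compound 4 both stop at a limit, so the step between them cannot be read: the limit of > 100000 nM in this assay, at which 3 of the 4 values shown sit.

Still open, from the compounds shown here alone, is whether replacing that phosphorus-bearing group with hydrogen changes anything on the core of compound 3, as it does on the core of compound 1.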